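Series notes: N-methylation of the cyanoguanidine chain

A few compounds are considered here, and "the series" means these few. Any claim that something is new, unique, unknown or untested is made for them only; others in the source may bear on it.

The series shares one core, seen in compound 1 `CS/C(=N\C#N)NCc1ccc(Cl)nc1`, which in a physicochemical assay for lipophilicity, using the shake flask method, measured as octanol-water partition, at 23 degrees C (on this read-out higher numbers stand for higher lipophilicity and lower numbers for lower lipophilicity), gives 1.27. Compound 2 `CCN/C(=N\C#N)NCc1ccc(Cl)nc1` gives 0.86 and compound 3 `CN(C)/C(=N\C#N)NCc1ccc(Cl)nc1` gives 0.66. Compound 2 stands second highest of the three: the step of a number 0.41 log units lower from compound 1 to compound 2 (beyond the scatter) lies beyond the scatter, whereas a number 0.20 log units lower from compound 2 to compound 3 (within the scatter) lies within it. Compound 4 `CCN/C(=N\C#N)N(C)Cc1ccc(Cl)nc1` differs from compound 2 by methyl in place of hydrogen on an amine nitrogen. For the measured compounds named here, no measured step touches this nitrogen; all three, a number 0.41 log units lower from compound 1 to compound 2 (beyond the scatter), a number 0.61 log units lower from compound 1 to compound 3 (beyond the scatter) and a number 0.20 log units lower from compound 2 to compound 3 (within the scatter), vary the group on the doubly bonded carbon, so they do not bear directly on the change. On general grounds a modest rise is expected, a number 0.34 log units higher from compound 2 to compound 4 (beyond the scatter). Compound 4 is estimated at 1.2, range 0.8 to 1.6.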

Compound 4, partition coefficient: 1.02
Estimate against measurement, compound 4: 0.18 log units above, and the stated range covers the measured number.
By their numbers in this assay, from the lowest: compounds 3, 2, 4 and 1 (each within the scatter of the next, the first and the last beyond it).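

Methyl in place of hydrogen on this amine nitrogen, the first change at this position, gives a number 0.16 log units higher from compound 2 to compound 4 (within the scatter) in this assay and so does not separate the two compounds. On the doubly bonded carbon, by contrast, ethylamino in place of methylsulfanyl gives a number 0.41 log units lower from compound 1 to compound 2 (beyond the scatter) and does exceed the scatter. Nothing available explains the size of the methyl step. Open, as far as these compounds go, is whether a longer chain such as propyl on this nitrogen would also stay within the scatter, and whether methyl here would read the same with methylsulfanyl on the doubly bonded carbon.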